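From ethoxycarbonyl to cyclohexyloxycarbonyl in one small series

This account rests on a few compounds, and the source may have more. Where it says the series, first, only, none or still open, it means among the compounds named here.

In a functional assay on HepG2 cells (Homo sapiens) for inhibition, read by scintillation counting, with a stated time of 2 h (on this read-out lower numbers stand for stronger inhibition and higher numbers for weaker inhibition), compound 1 (`CCNC(=O)Nc1sc2ccccc2c1C(=O)N1CCN(C2CCN(C(=O)CC)CC2)CC1`) has no numerical result ("not determined" (no result reported)). For the measured compounds named here, compound 2 (`CCNC(=O)Nc1sc2ccccc2c1C(=O)N1CCN(C2CCN(C(=O)OCC)CC2)CC1`) gives 228 nM and thus holds the only number available, so its rank cannot yet be judged. Compound 3 (`CCNC(=O)Nc1sc2ccccc2c1C(=O)N1CCN(C2CCN(C(=O)OC3CCCCC3)CC2)CC1`) carries cyclohexyl in place of ethyl on an oxygen next to a carbonyl group. Going by the values given here, no measured step is available as a guide, so in this assay only a small shift toward stronger inhibition is expected, an estimated 1.8-fold lower number from compound 2 to compound 3 (0.24 log units; within the scatter) that may not clear the usual scatter. Compound 3 is expected at 130 nM (estimated range 35 nM to 500 nM).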

Compound 3, half-maximal inhibitory concentration: 635 nM
Beside the measured number, compound 3's estimate is 4.9-fold (0.69 log units) below it, and the stated range ends below it.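

Putting cyclohexyl in place of ethyl on an oxygen next to a carbonyl group gives a 2.8-fold higher number from compound 2 to compound 3 (0.44 log units; beyond the scatter) in this assay, a step toward weaker inhibition that lies beyond the scatter. The position therefore responds to this change, yet compound 3 retains a measurable inhibitory concentration with the added ring. Nothing in the available evidence accounts for the loss. Steps involving compound 1 cannot be read. Going by these compounds, whether phenyl or a cyclohexyl ring carrying an amine would behave like cyclohexyl at this oxygen remains open.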